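Swapping Chloro for Methoxy at a Limit of Measurement

The source may hold more compounds than are shown below. What is called first, only, known or untested is meant among the compounds shown, and "the series" means these compounds.

Measured in a functional assay on HL-60 cells (Homo sapiens) for antiproliferative activity, read by MTT assay, with a stated time of 72 h (on this read-out higher numbers stand for weaker inhibition and lower numbers for stronger inhibition), where every value is a limit and not a number:
- compound 1 `COc1cc(-c2ncnn2-c2ccc(Cl)cc2Cl)cc(OC)c1OC`: > 10000 nM
- compound 2 `COc1cc(-c2ncnn2-c2ccc(N)cc2)cc(OC)c1OC`: > 10000 nM
- compound 3 `COc1cc(-c2ncnn2-c2ccc(Cl)cc2)cc(OC)c1OC`: > 10000 nM

Compound 3 offers only a limit, > 10000 nM. Its place in the series cannot be ranked, since compounds 1, 2 and 3 all stand at the limit of > 10000 nM in this assay, at which 3 of the 3 values shown sit.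

The next compound, compound 4 `COc1ccc(-n2ncnc2-c2cc(OC)c(OC)c(OC)c2)cc1`, has methoxy in place of chloro on an aromatic carbon, para to a large group: methoxy in place of chloro on an aromatic carbon.

The nearest measured change involves the same chloro group: a step that the two limits leave unreadable from compound 2 to compound 3. Two further changes also bear on the question: a step that the two limits leave unreadable from compound 1 to compound 3 and a step that the two limits leave unreadable from compound 1 to compound 2. None has a readable size, and none involves methoxy, so they cannot fix the size of the next step. In this assay, compound 4 may therefore stay at the same limit, or it may give a number showing stronger inhibition.

Highly uncertain in size, the change toward stronger inhibition is expected to be an at least 6.6-fold lower number from compound 3 to compound 4 (0.82 log units; beyond the scatter).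

For compound 4, the estimated value is 1500 nM, with an expected range from 40 nM to 10000 nM.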

Compound 4, half-maximal inhibitory concentration: 6200 nM
Compound 4: the middle estimate sits 4.1-fold (0.62 log units) below what was measured; low and high end bracket the measured number.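

In this assay, for the compounds shown here, compound 4 gives 6200 nM, the first value in this set that is a number and not a limit, so this aromatic carbon, para to a large group, can carry a group that gives a readable result. Methoxy in place of chloro gives an at least 1.6-fold lower number from compound 3 to compound 4 (0.20 log units; that floor lies within the scatter), methoxy in place of amino gives an at least 1.6-fold lower number from compound 2 to compound 4 (0.20 log units; that floor lies within the scatter), and 4-methoxyphenyl in place of 2,4-dichlorophenyl gives an at least 1.6-fold lower number from compound 1 to compound 4 (0.20 log units; that floor lies within the scatter), and each of these is only a floor on the size of the step. The steps among the other compounds cannot be read, as all of them share one limit: the limit of > 10000 nM in this assay, at which 3 of the 4 values shown sit.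

As far as these compounds go, how far the true values of those compounds lie from compound 4 remains open. Also open, from the compounds shown here alone, is whether a hydroxy or an ethoxy group at this place would give a lower or a higher number than methoxy.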